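Pyridin-4-yl to 4-Cyanophenyl on a Shared Core

The compounds below may be only part of what the source reports. "The series", "measured", "known", "first", "only" and "open" are said of these compounds alone.

Of the compounds shown here, two built on one shared core have been tested in a functional assay on Hep 3B2 cells (Homo sapiens) for inhibition, read by sulforhodamine B assay, with a stated time of 72 h, tested at 10 uM; on this read-out higher numbers stand for more inhibition at the one concentration tested (going by the name of the read-out) and lower numbers for less inhibition. Compound 1 `C[C@H](Nc1ncnc2[nH]cnc12)c1nn(-c2ccncc2)c2cc(F)ccc12` gives 5% in this assay. Compound 2 `C[C@H](Nc1ncnc2[nH]cnc12)c1nn(-c2cccnc2)c2cc(Cl)ccc12` gives 13% in this assay. Both numbers are small, and the gap between them lies within the usual scatter of repeated measurements, so the two compounds cannot be told apart on this read-out; compound 1 carries the smaller of the two numbers only in a nominal sense.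

Compound 3 `C[C@H](Nc1ncnc2[nH]cnc12)c1nn(-c2ccc(C#N)cc2)c2cc(F)ccc12` has not yet been measured. It differs from compound 1 in one place: 4-cyanophenyl in place of pyridin-4-yl on an aromatic nitrogen. Going by the values given here, no step between two measured compounds is available to gauge what this change does, so the expectation rests only on the two measured compounds, both of which show little inhibition. Because compound 1 gives 5%, compound 3 is expected to stay in the same low region, with a step of a number 5 percentage points higher from compound 1 to compound 3 (within the scatter) that is not expected to reach beyond the scatter. The estimate for compound 3 in this assay is 10%, with a range from 0% to 30%.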

Compound 3, a percentage reported as inhibition, at one concentration (the size of the read-out at that concentration, not a potency): 46%
For compound 3 the middle estimate is 36 percentage points below the measured one; measured number outside the range, above it.
By their numbers in this assay, from the lowest: compounds 1 and 2 (each within the scatter of the next); then compound 3.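

In this assay, putting 4-cyanophenyl in place of pyridin-4-yl on the aromatic nitrogen of the shared core gives a number 41 percentage points higher from compound 1 to compound 3 (beyond the scatter), the first difference in this small set that stands clear of the scatter. The group on this nitrogen is therefore a place where the read-out can respond strongly, something the earlier low and indistinguishable numbers gave no sign of. Nothing on hand explains the rise, and this single swap changes several things at once: the ring nitrogen leaves, a ring of carbon only enters, and a nitrile with its triple bond comes with it.

From the compounds shown here alone, what stays open is which of these parts carries the rise, and a plain phenyl ring, or a phenyl ring with an amine or a carboxylic acid where the nitrile stands, would help to separate them. It is also open whether this rise would carry over to a core with chlorine in place of fluorine, and, with one concentration per compound, how potent any of these compounds is.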